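The source may hold more compounds than are shown below. What is called first, only, known or untested is meant among the compounds shown, and "the series" means these compounds.

Working notes on the series. The compounds share one core: compound 1 `COc1ccc(Nc2nc(Oc3cccc(NC(=O)/C=C/C(C)C)c3)c3sccc3n2)cc1`, compound 2 `C/C=C/C(=O)Nc1cccc(Oc2nc(Nc3cccc(OC)c3)nc3ccsc23)c1`, compound 3 `CC/C=C/C(=O)Nc1cccc(Oc2nc(Nc3cccc(OC)c3)nc3ccsc23)c1` and the unmeasured compound 4 `COc1cccc(Nc2nc(Oc3cccc(NC(=O)/C=C/C(C)C)c3)c3sccc3n2)c1`. In a functional assay on A549 cells (Homo sapiens) for inhibition, read by MTT assay, with a stated time of 72 h (a lower number here means a stronger inhibitor, a higher number a weaker inhibitor), compound 1 gives 37900 nM, compound 2 gives 10500 nM and compound 3 gives 19600 nM. Compound 3 thus stands second highest of the three numbers, and its gaps to both compound 2 and compound 1 are within the scatter, so no order among them can be read.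

The change to compound 4 is methyl in place of hydrogen on a saturated chain carbon bound to a double-bonded chain carbon and a saturated chain carbon. Among the compounds with values here, the only measured step bearing on it is the earlier chain extension, a 1.9-fold higher number from compound 2 to compound 3 (0.27 log units; within the scatter), which itself stayed within the scatter. Compound 1 carries the same 3-methylbut-1-en-1-yl chain as compound 4 with the methoxy placed differently, and its value sits close to that of compound 3.

On this basis no step beyond the scatter is expected in this assay; the expected step is a 1.3-fold higher number from compound 3 to compound 4 (0.11 log units; within the scatter). Compound 4 is therefore estimated at 25000 nM, within 8000 nM to 75000 nM.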

Compound 4, half-maximal inhibitory concentration: 37100 nM
Compound 4: the middle estimate sits 1.5-fold (0.17 log units) below what was measured; low and high end bracket the measured number.
By their numbers in this assay, from the lowest: compounds 2, 3, 4 and 1 (each within the scatter of the next, the first and the last beyond it).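

In this assay, within the data shown here, the isopropyl chain end gives the first step at this position that clears the scatter when set against the methyl chain end (a 3.5-fold higher number from compound 2 to compound 4 (0.55 log units; beyond the scatter)), whereas the same end set against ethyl stays within it (a 1.9-fold higher number from compound 3 to compound 4 (0.28 log units; within the scatter)). The size of the step therefore depends on the comparison: only the span from methyl to isopropyl is readable, and the single added methyl is not. With the 3-methylbut-1-en-1-yl chain held fixed, 3-methoxyphenyl in place of 4-methoxyphenyl on the nitrogen leaves the two values indistinguishable (a 1.0-fold lower number from compound 1 to compound 4 (0.01 log units; within the scatter)), and no measurement at hand accounts for any of these steps.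

As far as these compounds go, whether a longer chain or an amine at the chain end would extend this trend stays open. So does whether the step from methyl to isopropyl holds outside this assay.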